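A few compounds are considered here, and "the series" means these few. Any claim that something is new, unique, unknown or untested is made for them only; others in the source may bear on it.

Measured compounds in an assay on isolated protein for inhibition of protoporphyrinogen oxidase (Homo sapiens), read by capillary electrophoresis; on this read-out lower numbers stand for stronger inhibition and higher numbers for weaker inhibition:
- compound 1 `C#CCSc1nc2cc(-n3nc(C(C)(C)C)sc3=O)c(F)cc2s1` gives 9730 nM
- compound 2 `CCOC(=O)CSc1nc2cc(-n3nc(C(C)(C)C)sc3=O)c(Cl)cc2s1` gives 5820 nM
- compound 3 `CCOC(=O)CCCSc1nc2cc(-n3nc(C(C)(C)C)sc3=O)c(Cl)cc2s1` gives 17700 nM

Compound 3 stands at the highest number of the three in this assay; compound 1 lies within the scatter of it, compound 2 clearly lower. Within the data shown here, the one step with a direct bearing is the chain extension on the sulfur, a 3.0-fold higher number from compound 2 to compound 3 (0.48 log units; beyond the scatter): lengthening the ester-bearing chain pushed the number up.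

Compound 4 `C#CCSc1nc2cc(-n3nc(C(C)(C)C)sc3=O)c(Cl)cc2s1` is not yet measured. Relative to compound 3 it carries ethynyl in place of 2-(ethoxycarbonyl)ethyl on a saturated chain carbon bound to a sulfur. This removes the ester chain altogether and leaves a short propargyl on the sulfur, so the step runs against the direction seen from compound 2 to compound 3. Compound 1 already shows the propargyl group on the core with fluorine, and its number is within the scatter of compound 3; compound 2 shows that the chlorine-bearing core with a short sulfur substituent gives the lowest number in this set. Taken together, a moderate drop is expected: a 2.5-fold lower number from compound 3 to compound 4 (0.40 log units; beyond the scatter).

The estimate for compound 4 in this assay is therefore 7000 nM, with a likely range from 3000 nM to 16000 nM.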

Compound 4, inhibition constant: 21400 nM
For compound 4 the middle estimate is 3.1-fold (0.49 log units) below the measured one, outside the stated range (above it).
By their numbers in this assay, from the lowest: compounds 2, 1, 3 and 4 (each within the scatter of the next, the first and the last beyond it).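

In this assay, on the chloro core, swapping the long ester chain for the short propargyl on the sulfur gives no readable change (a 1.2-fold higher number from compound 3 to compound 4 (0.08 log units; within the scatter)), so a short substituent at this place does not by itself go with the lower number of compound 2, and the ethoxycarbonyl of compound 2 and the ethynyl of compound 4 are clearly separated (a 3.7-fold higher number from compound 2 to compound 4 (0.57 log units; beyond the scatter)). With propargylsulfanyl held constant, the series also gains its first direct reading on the aromatic halogen: chloro in place of fluoro raises the number beyond the scatter (a 2.2-fold higher number from compound 1 to compound 4 (0.34 log units; beyond the scatter)), a modest step measured on this one sulfur substituent only. No measurement at hand accounts for either the ester or the halogen result.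

From the compounds shown here alone, whether the step from chloro to fluoro keeps its direction and size with an ethoxycarbonyl chain on the sulfur remains open, as does the outcome with a hydrogen on that aromatic carbon. Going by these compounds, it is also open whether a carboxylic acid or a primary amide in place of the ethyl ester on the short chain would stay near compound 2 or move towards compound 4.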